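Bromo to methyl on the benzyloxy ring of the tetralone series

A few compounds are considered here, and "the series" means these few. Any claim that something is new, unique, unknown or untested is made for them only; others in the source may bear on it.

Among the measured compounds shown here, compound 1 `O=C1CCCc2cc(OCc3ccc(Br)cc3)ccc21` gives the lowest of the two numbers so far. In an assay on isolated protein for inhibition of Amine oxidase [flavin-containing] A (Homo sapiens), read by fluorescence and spectrophotometry, with a stated time of 30 min (a lower number here means a stronger inhibitor, a higher number a weaker inhibitor), compound 1 gives 311 nM, and compound 2 `O=C1CCCc2cc(OCc3cccc(I)c3)ccc21` in this assay gives 1290 nM, a higher number that lies beyond the usual scatter. Compound 3 `Cc1ccc(COc2ccc3c(c2)CCCC3=O)cc1` has not yet been measured in this assay. It differs from compound 1 by methyl in place of bromo on an aromatic carbon, the change sitting on an aromatic carbon of a six-membered aromatic ring of carbon only, para to a large group. For the measured compounds named here, no measured pair shows this change, so the expectation rests on compound 1 alone. The replacement keeps the count of heavy atoms, donors and acceptors unchanged, and a small step is expected, if any, toward a somewhat higher number than compound 1, though a step inside the scatter is equally plausible. For compound 3 the estimated value in this assay is 450 nM, within a range of 150 nM to 1400 nM, which corresponds to an expected step of a 1.4-fold higher number from compound 1 to compound 3 (0.16 log units; within the scatter).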

Compound 3, half-maximal inhibitory concentration: 2090 nM
Estimate against measurement, compound 3: 4.6-fold (0.67 log units) below; measured number outside the range, above it.
By their numbers in this assay, from the lowest: compound 1; then compounds 2 and 3 (each within the scatter of the next).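

In this assay, this position is not indifferent to the group it carries: methyl in place of bromo, on an aromatic carbon para to a large group, gives (a 6.7-fold higher number from compound 1 to compound 3 (0.83 log units; beyond the scatter)). The exchange leaves the heavy-atom, donor and acceptor counts unchanged, so these counts alone do not separate the two compounds, and the identity of the group matters here. Of the two groups, bromo gives the lower number, and nothing at hand bears on what lies behind the difference.

Still open, as far as these compounds go, is whether other groups at this place, such as chloro, methoxy or an amine, would fall nearer compound 1 or nearer compound 3. From the compounds shown here alone, it is also open whether the same exchange of bromo for methyl would give a step of similar size on another core.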